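Removing a Methyl Group: Expected Effect on Cell Toxicity

The source may report more compounds than this note shows. Statements on the series, on what has been measured and on what is new or still open speak of the compounds shown alone.

Compound 1 `N/N=C1\NCCN1c1ccccc1Cl` and compound 2 `Cc1ccc(N2CCN/C2=N\N)cc1` share a core. In an ADME assay on Vero cells (Chlorocebus sabaeus) for cytotoxicity, with a stated time of 72 h, tested at 10 ug/mL (on this read-out higher numbers stand for a stronger effect at the one concentration tested and lower numbers for a weaker effect), compound 1 gives 0%. In this assay compound 2 gives 0%, level with compound 1 within the scatter. Compound 3 `N/N=C1\NCCN1c1ccccc1` differs from compound 2 by hydrogen in place of methyl on an aromatic carbon. For the measured compounds named here, no step between measured compounds is known, so the expectation rests on compound 2 alone. Because compound 2 gives 0%, no step beyond the scatter is expected. The estimated step of no change at the digits printed from compound 2 to compound 3 (within the scatter) is essentially none. In this assay compound 3 is expected at 0%, between 0% and 10%.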

Compound 3, a percentage reported as inhibition, at one concentration (the size of the read-out at that concentration, not a potency): 0%
The estimate for compound 3 equals the measured number at the digits printed, within the range that was stated.
By their numbers in this assay, from the lowest: compounds 1, 2 and 3 (each within the scatter of the next).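

In this assay, hydrogen in place of methyl on an aromatic carbon gives a clear reading (no change at the digits printed from compound 2 to compound 3 (within the scatter)), and hydrogen in place of chloro gives another (no change at the digits printed from compound 1 to compound 3 (within the scatter)). Compound 3 therefore supplies the plain hydrogen comparison for both compounds, which the earlier pair could not provide, and neither methyl nor chloro separates from hydrogen on this read-out. Nothing available explains these readings. Going by these compounds, whether an amine, a carboxylic acid or a longer chain on this aromatic carbon would read differently stays open.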